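A few compounds are considered here, and "the series" means these few. Any claim that something is new, unique, unknown or untested is made for them only; others in the source may bear on it.

Measured in an ADME assay on NIH3T3 cells (Mus musculus) for cytotoxicity, read by MTT assay, with a stated time of 24 h; a higher number here means a weaker inhibitor, a lower number a stronger inhibitor:
Compound 1 `O=C(CSc1ncccn1)N/N=c1/scc(-c2ccc([N+](=O)[O-])cc2)n1-c1ccccc1`: 193 ug/mL
Compound 2 `O=C(CSc1nnnn1-c1ccccc1)N/N=c1/scc(-c2ccc(Cl)cc2)n1-c1ccccc1`: 313 ug/mL

Going by the values given here, compound 2 gives 313 ug/mL, the higher of only two numbers, but it lies within the usual scatter of compound 1, so the two cannot be told apart. Compound 3 `O=C(CSc1ncccn1)N/N=c1/scc(-c2ccc(Cl)cc2)n1-c1ccccc1` has pyrimidin-2-yl in place of 1-phenyl-1H-tetrazol-5-yl on a sulfur. Among the compounds with values here, no measured pair shows this change alone. Compound 1 also carries pyrimidin-2-yl there and gives 193 ug/mL, so no large shift seems likely. In this assay, the expected step is a 1.4-fold lower number from compound 2 to compound 3 (0.13 log units; within the scatter), a slight fall not beyond the scatter. Compound 3 is expected near 230 ug/mL, with an estimated range of 110 ug/mL to 450 ug/mL.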

Compound 3, half-maximal inhibitory concentration: 397 ug/mL
Estimate against measurement, compound 3: 1.7-fold (0.24 log units) below, within the range that was stated.
By their numbers in this assay, from the lowest: compounds 1, 2 and 3 (each within the scatter of the next, the first and the last beyond it).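

In this assay, pyrimidin-2-yl in place of 1-phenyl-1H-tetrazol-5-yl on a sulfur gives a 1.3-fold higher number from compound 2 to compound 3 (0.10 log units; within the scatter), so this pair shows that the two groups cannot be told apart here, despite the smaller size of pyrimidin-2-yl. Chloro in place of nitro on an aromatic carbon gives a 2.1-fold higher number from compound 1 to compound 3 (0.31 log units; beyond the scatter), a modest step and the only one here that clears the scatter. Nothing measured here accounts for either step.

From the compounds shown here alone, whether an amine or a methoxy group on that aromatic carbon would shift the number further remains open. So does whether a simple methyl group on the sulfur would behave like the two aromatic rings.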